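The source may report more compounds than this note shows. Statements on the series, on what has been measured and on what is new or still open speak of the compounds shown alone.

Three compounds of the series carry numbers in a functional assay on the whole organism with Canis familiaris (Canis lupus familiaris) as the target, at a dose of 2 mg/kg by the intravenous route; a higher number here means a stronger effect of the compound at the dose given, a lower number a weaker effect. Compound 1 `Cc1ccn2c(C)c(C)nc2c1OCc1ccccc1` gives 70% in this assay; compound 2 `Cc1nc2c(OCc3ccccc3)cccn2c1N` gives 97%; compound 3 `Nc1cnc2c(OCc3ccccc3)cccn12` gives 81%. Compound 3 stands second of the three: compound 1 sits below it beyond the scatter, compound 2 above it beyond the scatter. For the measured compounds named here, the one step between measured compounds that differ in a single place runs from compound 2 to compound 3, hydrogen in place of methyl on an aromatic carbon, and it cost a number 16 percentage points lower from compound 2 to compound 3 (beyond the scatter).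

Compound 4 `CC(C)c1nc2c(OCc3ccccc3)cccn2c1N` differs from compound 3 by isopropyl in place of hydrogen on an aromatic carbon. Going by the values given here, the only step that bears on it is the one from compound 2 to compound 3, read in reverse: methyl in place of hydrogen on that carbon brought a modest gain. Among the compounds with values here, no measured pair tests isopropyl there, so whether the gain carries over is untested. Compound 4 is therefore expected to show a modest rise, estimated as a number 7 percentage points higher from compound 3 to compound 4 (within the scatter). Compound 4 is expected to give about 88%, estimated between 70% and 100%.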

Compound 4, a percentage reported as inhibition, in the whole organism at one dose (the size of the read-out at that dose, not a potency): 24%
Compound 4: middle estimate off by 64 percentage points, on the high side; the measured number lies below the stated range.
By their numbers in this assay, from the lowest: compound 4; then compound 1; then compound 3; then compound 2.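

In this assay, the aromatic carbon next to the ring atom that bears an amino group responds strongly to what it carries: isopropyl in place of hydrogen gives a number 57 percentage points lower from compound 3 to compound 4 (beyond the scatter) and isopropyl in place of methyl gives a number 73 percentage points lower from compound 2 to compound 4 (beyond the scatter) in the same series. The earlier step, with a number 16 percentage points lower from compound 2 to compound 3 (beyond the scatter) on losing the methyl, had shown only a modest dependence on this carbon, whereas the values now rank methyl over hydrogen over isopropyl, so the gain with methyl does not carry over to isopropyl. No measurement on these compounds accounts for this reversal.

From the compounds shown here alone, whether the fall sets in gradually or abruptly with the substituent remains open, and ethyl or cyclopropyl on this carbon would help to settle that. Also open, going by these compounds, is whether a polar group there, such as hydroxymethyl, would follow methyl or isopropyl.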